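Enone series on K562: amino to difluoro exchange

A few compounds are considered here, and "the series" means these few. Any claim that something is new, unique, unknown or untested is made for them only; others in the source may bear on it.

Compound 1 `COc1cc(-c2cc(/C=C/C(=O)c3ccc(N)cc3)[nH]n2)cc(OC)c1OC` and compound 2 `COc1ccc(-c2cc(/C=C/C(=O)c3ccc(N)cc3)[nH]n2)cc1OC` share the enone-linked core and differ only in that compound 2 carries hydrogen in place of methoxy on an aromatic carbon. In a functional assay on K562 cells (Homo sapiens) for cytotoxicity, read by sulforhodamine B assay, with a stated time of 48 h, tested at 100 uM (a lower number here means a stronger effect, a higher number a weaker effect of the compound at the concentration tested), compound 1 gives -3% and compound 2 gives -3%; the step of no change at the digits printed from compound 1 to compound 2 (within the scatter) is within the scatter, so compound 1 stands level with compound 2 and neither can be ranked against the other.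

Compound 3 `COc1cc(-c2cc(/C=C/C(=O)c3ccc(F)c(F)c3)[nH]n2)cc(OC)c1OC` is not yet measured. Its difference from compound 1 is 3,4-difluorophenyl in place of 4-aminophenyl on a carbonyl carbon. Within the data shown here, none of the measured steps touches the aryl group on the carbonyl carbon: the single step from compound 1 to compound 2 concerns an aromatic methoxy on the other end of the core and was flat. Among the measured compounds shown here, there is therefore no measured precedent for this exchange, and the expectation rests only on the two measured values, which sit together.

The estimate for compound 3 is -3%, with a range from -40% to 25%, which is expected to mean a step of no change at the digits printed from compound 1 to compound 3 (within the scatter) in this assay, not beyond the scatter but with a wide band because nothing measured bears on the change.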

Compound 3, a percentage reported as activity, at one concentration (the size of the read-out at that concentration, not a potency): -7%
Compound 3: middle estimate off by 4 percentage points, on the high side; the measured number falls inside the stated range.
By their numbers in this assay, from the lowest: compounds 3, 1 and 2 (each within the scatter of the next).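

In this assay, among these compounds, 3,4-difluorophenyl in place of 4-aminophenyl on a carbonyl carbon gives a number 4 percentage points lower from compound 1 to compound 3 (within the scatter), which is the first reading at this position and does not separate the two compounds. The read-out therefore stays within the scatter even though the group that leaves carries 1 hydrogen-bond donor and 1 hydrogen-bond acceptor and the group that enters carries neither, so at this one tested concentration neither that count nor the identity of this aryl group shows up in the number. Nothing available bears on the reason for this flat result.

On these data alone, whether a carboxylic acid or a morpholine on this aryl group, or a plain alkyl chain in its place on the carbonyl carbon, would move the read-out beyond the scatter remains open. Also open, as far as these compounds go, is whether the flat step on the aromatic methoxy, no change at the digits printed from compound 1 to compound 2 (within the scatter), holds when 3,4-difluorophenyl sits on the carbonyl carbon.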